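A few compounds are considered here, and "the series" means these few. Any claim that something is new, unique, unknown or untested is made for them only; others in the source may bear on it.

Compound 1 `O=Cc1cn(Cc2cccc(C(F)(F)F)c2)c2ccccc12`: 1780 nM
Compound 2 `OCc1cn(Cc2cccc(Cl)c2)c2ccccc12`: 160 nM
Compound 3 `OCc1cn(Cc2ccc(Br)cc2)c2ccccc12`: 390 nM

These three compounds were tested in a functional assay on T29Kt1 cells (Homo sapiens) for cytotoxicity, read by sulforhodamine B assay, with a stated time of 3 days; a higher number here means a weaker inhibitor, a lower number a stronger inhibitor. Compound 3, at 390 nM, gives the second highest of the three numbers, so it sits in the middle. Compound 2 gives a lower number, 160 nM, and compound 1 a higher one, 1780 nM. Both gaps from compound 3 lie beyond the usual scatter of repeated measurements. However, no two of these measured compounds differ in only one place, so none of the gaps can be tied to a single structural change.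

The next compound, compound 4 `COc1ccc(Cn2cc(CO)c3ccccc32)cc1`, differs from compound 3 in one place: methoxy in place of bromo on an aromatic carbon, para to a large group (methoxy in place of bromo on an aromatic carbon). No measurement here shows what this swap does on its own, so the direction is uncertain. The best available anchor is compound 3 itself at 390 nM, and no change beyond the scatter is expected. The expected step is a 1.1-fold higher number from compound 3 to compound 4 (0.03 log units; within the scatter). In this assay the estimated value for compound 4 is 420 nM, with an expected range of 140 nM to 1250 nM.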

Compound 4, half-maximal inhibitory concentration: 63 nM
For compound 4 the middle estimate is 6.7-fold (0.82 log units) above the measured one, and the stated range ends above it.
By their numbers in this assay, from the lowest: compound 4; then compound 2; then compound 3; then compound 1.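

In this assay, methoxy in place of bromo on an aromatic carbon, para to a large group, gives a 6.2-fold lower number from compound 3 to compound 4 (0.79 log units; beyond the scatter), the first gap in this set that can be tied to a single structural change. It shows that this place on the ring is not indifferent to what sits there: a swap that adds only one heavy atom and brings in one hydrogen-bond acceptor moves the number beyond the usual scatter. No measurement at hand accounts for the drop, so it stands as an observation without an explanation.

The compounds shown leave open whether the lower number belongs to methoxy in particular or would also come with a hydroxyl group, an amine or a longer chain such as ethoxy at the same place, and how any of these would compare with a plain hydrogen there. Compound 1 and compound 2 cannot settle whether the step carries over to other compounds, as neither differs from compound 4 in only one place.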